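Cytotoxicity notes on the shared-core series

A few compounds are considered here, and "the series" means these few. Any claim that something is new, unique, unknown or untested is made for them only; others in the source may bear on it.

Measured so far:
compound 1 `O=C(c1ccccc1)c1ccc2nc(NCCO)[nH]c2c1` — > 30000 nM
compound 2 `O=C(CCC1CCNCC1)Nc1nc2ccc(C(=O)c3ccccc3)cc2[nH]1` — > 30000 nM
compound 3 `Nc1nc2ccc(C(=O)c3ccccc3)cc2n1C[C@H]1CCCN1` — > 30000 nM

In an ADME assay on CRL8155 cells (Homo sapiens) for cytotoxicity, read by resazurin assay, with a stated time of 72 h (a higher number here means that more compound is needed for the effect, a lower number that less compound is needed), compound 1 gives only a limit, > 30000 nM, not a number. Compound 2 likewise reaches only the limit of this assay, > 30000 nM. Compound 3 also returns only a limit in this assay, > 30000 nM. Compound 3 therefore stands exactly where the other two stand: the limit of > 30000 nM in this assay, at which 3 of the 3 values shown sit. Among the measured compounds shown here, no step between measured compounds can be drawn, since no pair differs in a single place, and with every value sitting at the same limit the three structures cannot be ordered against one another.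

The next compound, compound 4 `Nc1nc2ccc(C(=O)c3ccccc3)cc2n1CCN1CCCCC1`, is not yet measured in this assay. It differs from compound 3 as follows: (piperidin-1-yl)methyl in place of pyrrolidin-2-yl on a saturated chain carbon bound to an aromatic nitrogen. The change keeps the shared core and the benzoyl substituent untouched and alters only the saturated chain on the aromatic nitrogen.

With all three measured values at the limit, no step beyond the usual scatter is expected in this assay; compound 4 is expected to sit at the limit as well, so that the estimated step of a number no higher from compound 3 to compound 4 (the limit leaves the size open) is effectively none. The estimated value for compound 4 in this assay is 30000 nM, with a range from 10000 nM to 100000 nM, and most likely the assay will again report only a limit.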

Compound 4, half-maximal effective concentration: > 30000 nM
Compound 4 was reported as a limit; the forecaster's own chance of this, stated with the estimate: 80%; the middle value sits exactly at the limit.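

Compound 4 gives > 30000 nM in this assay as a limit only. No step can be read from compound 3 to compound 4, and the series stays where it stood: the limit of > 30000 nM in this assay, at which 4 of the 4 values shown sit.

The compounds shown leave open whether any structure on this shared core gives a readable value in this assay at all.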